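From compound 2 to compound 4: a small expected step

The source may report more compounds than this note shows. Statements on the series, on what has been measured and on what is new or still open speak of the compounds shown alone.

compound 1 `CCC(C)=C1C(=O)N(c2ccc(Cl)cc2)N(c2ccc(Cl)cc2)C1=O`: 66500 nM
compound 2 `COc1cccc(C=C2C(=O)N(c3ccc(Cl)cc3)N(c3ccc(Cl)cc3)C2=O)c1O`: 24300 nM
compound 3 `CC(=C1C(=O)N(c2ccc(Cl)cc2)N(c2ccc(Cl)cc2)C1=O)c1ccc(O)cc1`: 42800 nM

These three values come from a functional assay on MGC-803 cells (Homo sapiens) for cytotoxicity, read by MTT assay, with a stated time of 72 h (a higher number here means a weaker inhibitor, a lower number a stronger inhibitor), and compare compounds built on a shared core. Compound 2 at 24300 nM cannot be separated from compound 3 at 42800 nM on these numbers, while compound 1 at 66500 nM lies higher than compound 2 by more than the scatter.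

Compound 4 `COc1ccccc1C=C1C(=O)N(c2ccc(Cl)cc2)N(c2ccc(Cl)cc2)C1=O` has not yet been measured and differs from compound 2 at one place: 2-methoxyphenyl in place of 2-hydroxy-3-methoxyphenyl on a double-bonded chain carbon bound to a double-bonded ring carbon in which 2-methoxyphenyl takes the place of 2-hydroxy-3-methoxyphenyl on a double-bonded chain carbon bound to a double-bonded ring carbon.

Among the compounds with values here, no measured step makes this exact change. Within the data shown here, the only measured step is a 1.6-fold lower number from compound 1 to compound 3 (0.19 log units; within the scatter) and it exchanges other groups, so it is an indirect guide that shows no large response. On these data alone, no step beyond the scatter is therefore expected in this assay and the direction stays open, with a slight lean towards a higher number. The expected step is a 1.2-fold higher number from compound 2 to compound 4 (0.09 log units; within the scatter) on this estimate. For compound 4 the estimated value is 30000 nM with an expected range from 11000 nM to 70000 nM in this read-out.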

Compound 4, half-maximal inhibitory concentration: 28600 nM
The estimate for compound 4 lay 1.0-fold (0.02 log units) above the measured number; the range from low to high includes it.
By their numbers in this assay, from the lowest: compounds 2, 4, 3 and 1 (each within the scatter of the next, the first and the last beyond it).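

In this assay, within the data shown here, the exchange of 2-hydroxy-3-methoxyphenyl for 2-methoxyphenyl on a double-bonded chain carbon bound to a double-bonded ring carbon gives the first direct reading of a change in this group, a 1.2-fold higher number from compound 2 to compound 4 (0.07 log units; within the scatter). The group that leaves has 1 hydrogen-bond donor and 2 hydrogen-bond acceptors, and the group that enters has 0 hydrogen-bond donors and 1 hydrogen-bond acceptor. This pair therefore shows that these differences in heavy atoms, donors and acceptors can occur at this place without a step beyond the scatter in this read-out. No measurement available here accounts for this result.

The compounds shown leave open whether the same holds for other groups on this aromatic ring, such as an amine or a carboxylic acid, or for a simple phenyl carrying no oxygen at all, any of which might give a step beyond the scatter. They also leave open whether the pair would read the same way in any cell line other than the one in this assay.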